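Series notes: the step from compound 3 to compound 4

A few compounds are considered here, and "the series" means these few. Any claim that something is new, unique, unknown or untested is made for them only; others in the source may bear on it.

Measured so far in an assay on isolated protein (Oryctolagus cuniculus) with Thromboxane-A synthase (Homo sapiens) as the target, tested at 1 uM; a higher number here means more inhibition at the concentration tested (going by the name of the read-out), a lower number less inhibition:
compound 1 `CC(=O)Cn1nc(-c2cccnc2)c2ccccc2c1=O` gives 13%;
compound 2 `O=C(O)CCCn1nc(-c2cccnc2)c2ccccc2c1=O` gives 73%;
compound 3 `CCn1nc(-n2cncn2)c2ccccc2c1=O` gives 0%.

Compound 3 stands lowest of the three numbers in this assay, beyond the scatter below compound 1 and far below compound 2. For the measured compounds named here, the one step known, a number 60 percentage points higher from compound 1 to compound 2 (beyond the scatter), concerns the chain on the ring nitrogen and not the aromatic substituent, so it does not bear on the change at hand. Compound 4 `CCn1nc(-c2cncnc2)c2ccccc2c1=O` differs from compound 3 by pyrimidin-5-yl in place of 1H-1,2,4-triazol-1-yl on an aromatic carbon. Going by the values given here, no measured step touches this position; compound 1 and compound 2 differ from compound 3 in two places. With both short-chain compounds low, only a small rise is expected, a number 15 percentage points higher from compound 3 to compound 4 (beyond the scatter), giving for compound 4 an estimate of 15% within 0% to 40%.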

Compound 4, a percentage reported as inhibition, at one concentration (the size of the read-out at that concentration, not a potency): 26%
Compound 4: middle estimate off by 11 percentage points, on the low side; the range from low to high includes it.
By their numbers in this assay, from the lowest: compound 3; then compound 1; then compound 4; then compound 2.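

With the ethyl group held constant, the aromatic substituent on the shared core moves the read-out in this assay on its own: pyrimidin-5-yl in place of 1H-1,2,4-triazol-1-yl gives a number 26 percentage points higher from compound 3 to compound 4 (beyond the scatter). For the compounds shown here, the earlier step concerned only the chain on the ring nitrogen, so this is the first reading at this position. Nothing at hand accounts for the difference between these two rings.

Open, on these data alone, is how an amine at this position would compare with either ring. Also open, as far as these compounds go, is whether a longer chain ending in a carboxylic acid would change the standing of pyrimidin-5-yl.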